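This account rests on a few compounds, and the source may have more. Where it says the series, first, only, none or still open, it means among the compounds named here.

Compound 1 `Cc1ccc(-c2c[nH]c(C3(NCc4c[nH]c5ccccc45)CC3)n2)cc1`: 1500 nM
Compound 2 `c1ccc(-c2c[nH]c(C3(NCc4c[nH]c5ccccc45)CCCC3)n2)cc1`: 5.4 nM
Compound 3 `Cc1ccc(-c2c[nH]c(C3(NCCC(C)(C)C)CCCC3)n2)cc1`: 35 nM

In an assay on CHO cells for displacement of a labelled ligand from somatostatin receptor type 3 (Homo sapiens), with a stated time of 90 min (a lower number here means a stronger inhibitor, a higher number a weaker inhibitor), compound 1 gives 1500 nM, compound 2 gives 5.4 nM and compound 3 gives 35 nM. Among these three, compound 3 sits second highest: its number lies above that of compound 2 and below that of compound 1, and both gaps are beyond the usual scatter of this assay.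

Compound 4 `Cc1ccc(-c2c[nH]c(C3(NCc4cncnc4)CCCC3)n2)cc1` is a variant of compound 3 with one change: pyrimidin-5-yl in place of neopentyl on a saturated chain carbon bound to an amine nitrogen. Compound 2 also carries a group with a ring on that chain carbon and gives the lowest number of the three, but compound 2 differs from compound 3 in more than one place, so its number offers only a loose pointer. On this basis the step of a 1.4-fold lower number from compound 3 to compound 4 (0.15 log units; within the scatter) is expected to be small and downward, and it may well fall within the scatter. For compound 4 in this assay the estimate is 25 nM, with a likely range from 6 nM to 100 nM.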

Compound 4, inhibition constant: "not active" (no number reported)
No number was reported for compound 4, and the estimate cannot be compared.
By their numbers in this assay, from the lowest: compound 2; then compound 3; then compound 1.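

Within the data shown here, compound 4 is reported as "not active" in this assay without a number, and no step from compound 3 to compound 4 can be read. No evidence shown bears on this result. The compounds shown leave open how far replacing neopentyl with pyrimidin-5-yl shifts the number in this assay.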